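The compounds below may be only part of what the source reports. "The series", "measured", "known", "first", "only" and "open" are said of these compounds alone.

Compound 1 `Cc1cc(C)nc(N(COC(=O)C(C)(C)C)S(=O)(=O)c2ccc(N)cc2)n1`: 4.07 h; compound 2 `CCCN(CCC)Cc1cccc(C(=O)OCCOCn2cnc3c(=O)[nH]c(N)nc32)c1`: 0.0133 h; compound 3 `CCN(CC)Cc1cccc(C(=O)OCCOCn2cnc3c(=O)[nH]c(N)nc32)c1`: 0.125 h, all measured in an ADME assay on a cell-free system (plasma, Homo sapiens) for metabolic stability; on this read-out lower numbers stand for a shorter-lived compound and higher numbers for a longer-lived compound.

Compound 3 holds the second highest of the three numbers: compound 2 lies below it by a 9.4-fold higher number from compound 2 to compound 3 (0.97 log units; beyond the scatter), while compound 1 stands clearly above both. Compound 4 `CCCCN(CCCC)Cc1cccc(C(=O)OCCOCn2cnc3c(=O)[nH]c(N)nc32)c1` is compound 3 with dibutylamino in place of diethylamino on a saturated chain carbon bound to an aromatic carbon. Among the compounds with values here, only one measured step bears on this change, a 9.4-fold higher number from compound 2 to compound 3 (0.97 log units; beyond the scatter), and it went from dipropylamino to diethylamino, the opposite direction to the present one, with a size beyond the scatter. Going from diethylamino past dipropylamino to dibutylamino is therefore expected to lower the number in this assay, by about a 21-fold lower number from compound 3 to compound 4 (1.32 log units; beyond the scatter). Compound 4 is estimated at 0.006 h, expected within 0.0015 h to 0.03 h.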

Compound 4, half-life: 0.0383 h
Estimate against measurement, compound 4: 6.4-fold (0.81 log units) below, and the stated range ends below it.
By their numbers in this assay, from the lowest: compound 2; then compound 4; then compound 3; then compound 1.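

In this assay, dibutylamino still gives a 3.3-fold lower number from compound 3 to compound 4 (0.51 log units; beyond the scatter) when it replaces diethylamino, yet it gives a 2.9-fold higher number from compound 2 to compound 4 (0.46 log units; beyond the scatter) when it replaces dipropylamino. The number at this place therefore does not fall steadily with chain length: compound 4 goes against such a trend, and compound 2 stays lowest of the three amines. Nothing measured here accounts for this turn. As far as these compounds go, whether the number keeps rising with a longer chain such as dipentylamino, or how a cyclic amine such as piperidinyl compares at this place, remains open.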